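The compounds below may be only part of what the source reports. "The series", "measured", "known", "first", "only" and "open" are said of these compounds alone.

Measured so far in a functional assay on HT-29 cells (Homo sapiens) for cytotoxicity, read by MTT assay, with a stated time of 72 h; on this read-out higher numbers stand for weaker inhibition and lower numbers for stronger inhibition:
- compound 1 `CN(C)CCCNc1nc(-c2ccc(NC(=O)Nc3ccc(F)cc3)cc2)nc2c(Cl)c(Cl)sc12` gives 430 nM
- compound 2 `CN(C)CCCNc1nc(-c2ccc(NC(=O)Nc3ccc(Cl)cc3)cc2)nc2c(Cl)c(Cl)sc12` gives 330 nM
- compound 3 `CN(C)CCCNc1nc(-c2ccc(NC(=O)Nc3ccccc3Cl)cc2)nc2c(Cl)c(Cl)sc12` gives 820 nM

Compound 3 has the highest number of the three; against compound 1 the gap is within the scatter, against compound 2 it is a modest one beyond it. Compound 4 `CN(C)CCCNc1nc(-c2ccc(NC(=O)Nc3ccc(Cl)cc3Cl)cc2)nc2c(Cl)c(Cl)sc12` is made from compound 3 by chloro in place of hydrogen on an aromatic carbon: on an aromatic carbon of a six-membered aromatic ring of carbon only, meta to a chloro group and para to a large group, so 2-chlorophenyl becomes 2,4-dichlorophenyl. Within the data shown here, two measured steps bear on this. a 1.3-fold lower number from compound 1 to compound 2 (0.11 log units; within the scatter) shows that chloro at that position changes little, and a 2.5-fold higher number from compound 2 to compound 3 (0.40 log units; beyond the scatter) shows that compound 3 lost some ground when the chloro moved. Compound 4 keeps the 2-chloro and regains the 4-chloro, so a step back toward compound 2 is expected, a 1.8-fold lower number from compound 3 to compound 4 (0.26 log units; within the scatter), giving an estimated 450 nM for compound 4, within 200 nM to 1000 nM.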

Compound 4, half-maximal inhibitory concentration: 1320 nM
Beside the measured number, compound 4's estimate is 2.9-fold (0.47 log units) below it; the measured number lies above the stated range.
By their numbers in this assay, from the lowest: compounds 2, 1, 3 and 4 (each within the scatter of the next, the first and the last beyond it).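

In this assay, turning 2-chlorophenyl into 2,4-dichlorophenyl gives a 1.6-fold higher number from compound 3 to compound 4 (0.21 log units; within the scatter), so the added chloro does not bring back the lower number of the 4-chlorophenyl compound 2. Adding a 2-chloro to that 4-chlorophenyl gives a 4.0-fold higher number from compound 2 to compound 4 (0.60 log units; beyond the scatter), and replacing 4-fluorophenyl with 2,4-dichlorophenyl gives a 3.1-fold higher number from compound 1 to compound 4 (0.49 log units; beyond the scatter), so here the two chloro groups do not add up to a gain. Nothing measured here gives a reason for this. Still open, from the compounds shown here alone, is how a plain phenyl, or a methyl or methoxy group in place of these halogens, would compare.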